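A few compounds are considered here, and "the series" means these few. Any claim that something is new, unique, unknown or untested is made for them only; others in the source may bear on it.

Measured in a functional assay on SGC-7901 cells (Homo sapiens) for inhibition, read by MTT assay, with a stated time of 72 h; on this read-out lower numbers stand for stronger inhibition of growth and higher numbers for weaker inhibition of growth:
- Compound 1 `O[C@H](COCCOC[C@@H](O)Cc1cn(-c2cccs2)nn1)Cc1ccc(-c2ccccc2)cc1`: 33400 nM
- Compound 2 `O[C@H](COCCOC[C@@H](O)Cc1cn(-c2cncnc2)nn1)Cc1ccc(-c2ccccc2)cc1`: > 100000 nM
- Compound 3 `O[C@H](COCCOC[C@@H](O)Cc1cn(-c2cccnc2)nn1)Cc1ccc(-c2ccccc2)cc1`: 29800 nM

The value for compound 2 is a limit of the assay. Compound 3 stands level with compound 1, since a 1.1-fold lower number from compound 1 to compound 3 (0.05 log units; within the scatter).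

Compound 4 `O[C@H](COCCOC[C@@H](O)Cc1c[nH]nn1)Cc1ccc(-c2ccccc2)cc1` follows from compound 3 by hydrogen in place of pyridin-3-yl on an aromatic nitrogen. The measured steps only exchange one ring on that nitrogen for another, and none removes it. Beside the step above, there is an at least 3.3-fold lower number from compound 2 to compound 3 (0.52 log units; beyond the scatter), so the group there can matter in this assay. A modest move to a higher number is therefore expected. The estimated step is a 2.2-fold higher number from compound 3 to compound 4 (0.34 log units; beyond the scatter). For compound 4 the estimate is 65000 nM, with an expected range from 25000 nM to 170000 nM.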

Compound 4, concentration for 50% growth inhibition: > 100000 nM
Compound 4: no number, only a limit (the forecaster's own chance of this, stated with the estimate: 35%); at least 1.5-fold (0.18 log units) between middle value and limit.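

Compound 4 gives > 100000 nM in this assay as a limit of the assay and not a number. Removing the ring from the aromatic nitrogen altogether gives an at least 3.3-fold higher number from compound 3 to compound 4 (0.52 log units; beyond the scatter) and an at least 2.9-fold higher number from compound 1 to compound 4 (0.47 log units; beyond the scatter) and so shows, as the ring exchanges could not, that a readable value here requires a ring on that nitrogen, though compound 2 with pyrimidin-5-yl goes against any claim that every ring suffices. The step between compound 2 and compound 4 cannot be read, since both rest on the same limit: the limit of > 100000 nM in this assay, at which 2 of the 4 values shown sit.

Left open is whether a methyl or a benzyl group on that nitrogen would retain the readable values of compound 1 and compound 3. As far as these compounds go, how far compound 2 and compound 4 lie beyond their limit also remains unknown.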